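Compound 3 to compound 4: fluoro exchanged for methyl

The compounds below may be only part of what the source reports. "The series", "measured", "known", "first", "only" and "open" are said of these compounds alone.

Three compounds have been measured in a functional assay on HL-60 cells (Homo sapiens) for cytotoxicity, with a stated time of 24 h; a higher number here means that more compound is tolerated, a lower number that less compound is tolerated:

- compound 1 `COc1ccc(/C=C2\CCC/C(=C\c3ccccc3[N+](=O)[O-])C2=O)cc1`: 26000 nM
- compound 2 `O=C1/C(=C/c2ccc(Cl)cc2)CCC/C1=C\c1cccc([N+](=O)[O-])c1`: 3200 nM
- compound 3 `O=C1/C(=C/c2ccc(F)cc2)CCC/C1=C\c1ccc([N+](=O)[O-])cc1`: 32000 nM

Compound 3, at 32000 nM, lies within the scatter of compound 1, at 26000 nM. Compound 2 stands apart from compound 3, with a number lower by more than the scatter. The next compound to be tested is compound 4 `Cc1ccc(/C=C2\CCC/C(=C\c3ccc([N+](=O)[O-])cc3)C2=O)cc1`, which differs from compound 3 by methyl in place of fluoro on an aromatic carbon, so that 4-fluorophenyl becomes 4-methylphenyl. Within the data shown here, no measured pair differs in one place only, so the data offer no direct guide to this change. The expectation therefore starts from compound 3 at 32000 nM, and the range is kept wide on the low side, given compound 2 at 3200 nM. The estimated change, a 1.5-fold lower number from compound 3 to compound 4 (0.16 log units; within the scatter), is expected to stay within the scatter, with a slight lean towards a lower number. The expected value for compound 4 is 22000 nM, with an estimated range from 7000 nM to 50000 nM.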

Compound 4, half-maximal cytotoxic concentration: 27000 nM
Beside the measured number, compound 4's estimate is 1.2-fold (0.09 log units) below it; measured number inside the range.
By their numbers in this assay, from the lowest: compound 2; then compounds 1, 4 and 3 (each within the scatter of the next).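

In this assay, among these compounds, exchanging 4-fluorophenyl for 4-methylphenyl gives the only step here between compounds that differ in one place, and that step, a 1.2-fold lower number from compound 3 to compound 4 (0.07 log units; within the scatter), lies within the scatter. At this position, on an aromatic carbon para to a large group, fluoro and methyl therefore cannot be told apart in this read-out while the rest of the structure stays as in compound 3. Nothing available here accounts for this result.

The compounds shown leave open whether another group at this place, such as an amine or a carboxylic acid, would shift the number beyond the scatter. Among the compounds shown here, they also include no pair that traces the number of compound 2 at 3200 nM to a single change.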